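This account rests on a few compounds, and the source may have more. Where it says the series, first, only, none or still open, it means among the compounds named here.

Among the compounds with values here, in a functional assay on PC-3 cells (Homo sapiens) for cytotoxicity, read by MTT assay, with a stated time of 72 h (a higher number here means a weaker inhibitor, a lower number a stronger inhibitor), compound 3 `O=[N+]([O-])c1ccc(Nc2nc(SCc3ccc(C(F)(F)F)cc3)nc3ccccc23)cc1` gives 7900 nM, the lowest of the three numbers so far. Compound 1 `FC(F)(F)c1ccc(CSc2nc(Nc3ccccc3)c3ccccc3n2)cc1` gives 20000 nM, and compound 2 `FC(F)(F)c1ccc(CSc2nc(Nc3ccccc3C(F)(F)F)c3ccccc3n2)cc1` gives 34800 nM. Compound 4 `CCOc1ccc(Nc2nc(SCc3ccc(C(F)(F)F)cc3)nc3ccccc23)cc1` differs from compound 3 by ethoxy in place of nitro on an aromatic carbon. The measured step that bears on this most is a 2.5-fold lower number from compound 1 to compound 3 (0.40 log units; beyond the scatter), where the number fell once a nitro was present. Within the data shown here, the steps of a 1.7-fold higher number from compound 1 to compound 2 (0.24 log units; within the scatter) and a 4.4-fold lower number from compound 2 to compound 3 (0.64 log units; beyond the scatter) say nothing about an ethoxy, and no measured compound carries one. Removing the nitro is therefore expected to give back part of that modest gain, so compound 4 is expected at 15000 nM, between 5000 nM and 45000 nM, an expected step of a 1.9-fold higher number from compound 3 to compound 4 (0.28 log units; within the scatter).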

Compound 4, half-maximal inhibitory concentration: 32100 nM
Compound 4: middle estimate off by 2.1-fold (0.33 log units), on the low side; the measured number falls inside the stated range.
By their numbers in this assay, from the lowest: compound 3; then compounds 1, 4 and 2 (each within the scatter of the next).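

Swapping nitro for ethoxy at this aromatic carbon matters in this assay (a 4.1-fold higher number from compound 3 to compound 4 (0.61 log units; beyond the scatter)), so the group placed here can change the result. Ethoxy, however, does not separate from plain hydrogen (a 1.6-fold higher number from compound 1 to compound 4 (0.21 log units; within the scatter)), and replacing the whole 2-(trifluoromethyl)phenyl with 4-ethoxyphenyl also stays within the scatter (a 1.1-fold lower number from compound 2 to compound 4 (0.04 log units; within the scatter)), leaving nitro as the only group here that stands apart. Nothing shown explains this difference. As far as these compounds go, whether nitro is unique remains open, and a nitrile, an amine or a carboxylic acid at this carbon would test that.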